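Swapping Halogens on the Phenoxy Ring of Compound 2

The source may hold more compounds than are shown below. What is called first, only, known or untested is meant among the compounds shown, and "the series" means these compounds.

Measured so far:
compound 1 `Cc1nn(C)c(Oc2ccc(F)cc2)c1/C=N\OCc1c(Cl)c(-c2ccc(Cl)cc2)nn1C`: 80%
compound 2 `Cc1nn(C)c(Oc2ccc(Cl)cc2)c1/C=N\OCc1c(Cl)c(-c2ccc(Cl)cc2)nn1C`: 80%

In a functional assay on SMMC-7721 cells (Homo sapiens) for inhibition, read by MTT assay, with a stated time of 72 h, tested at 25 uM (a higher number here means more inhibition at the concentration tested (going by the name of the read-out), a lower number less inhibition), compound 1 gives 80% and compound 2 gives 80%; the step of no change at the digits printed from compound 1 to compound 2 (within the scatter) lies within the scatter, so compound 2 stands level with compound 1. Compound 3 `Cc1nn(C)c(Oc2ccc(Br)cc2)c1/C=N\OCc1c(Cl)c(-c2ccc(Cl)cc2)nn1C` differs from compound 2 by bromo in place of chloro on an aromatic carbon. Going by the values given here, the one step that bears on this, no change at the digits printed from compound 1 to compound 2 (within the scatter), was another halogen swap on the same ring and changed nothing beyond the scatter. Compound 3 is therefore expected to show a step of no change at the digits printed from compound 2 to compound 3 (within the scatter), that is none beyond the scatter, with an estimate of 80% (range 68% to 90%).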

Compound 3, a percentage reported as inhibition, at one concentration (the size of the read-out at that concentration, not a potency): 80%
Compound 3: the middle estimate sits on the measured number at the digits printed, within the range that was stated.
By their numbers in this assay, from the lowest: compounds 1, 2 and 3 (each within the scatter of the next).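

In this assay the swap to the larger halogen gives no change at the digits printed from compound 2 to compound 3 (within the scatter) and the swap across the whole series gives no change at the digits printed from compound 1 to compound 3 (within the scatter) as well. Fluoro, chloro and bromo on this ring carbon therefore stand level, extending what a single halogen swap showed earlier to all three compounds. Nothing available explains this lack of change.
Still open, on these data alone, is whether a group other than a halogen at this place, such as an amine, a methoxy group or a carboxylic acid, would keep this inhibition. A single tested concentration also leaves open whether the three compounds would still stand level at lower concentrations.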